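The source may hold more compounds than are shown below. What is called first, only, known or untested is meant among the compounds shown, and "the series" means these compounds.

Compound 1 `N#Cc1cc(-c2nc(C(c3ccc(F)cc3)c3ccc(F)cc3)sc2CC(=O)O)ccc1F` belongs to a small set of thiazole acetic acids tested in an in vitro functional assay on HEK285-7 cells for antagonist activity at prostaglandin D2 receptor 2 (Homo sapiens), read by BRET and beta-arrestin recruitment; a lower number here means a stronger inhibitor, a higher number a weaker inhibitor. In this assay compound 1 gives 520 nM. Its closest neighbour among the measured compounds is compound 3 `O=C(O)Cc1sc(CSc2ccccc2)nc1-c1ccc(Cl)cc1`, which in this assay gives 450 nM; the two values sit within the usual scatter of one another, so neither can be called the more potent. Compound 2 `CCC(c1ccccc1)c1nc(-c2ccc(Cl)cc2)c(CC(=O)O)s1` gives only a limit of the assay, > 100000 nM, and no number (the limit of > 100000 nM in this assay, at which 1 of the 3 values shown sits). Compound 1 thus stands with compound 3 at the measurable end of this set, well away from the limit shown by compound 2.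

Compound 4 `O=C(O)Cc1sc(C(c2ccc(F)cc2)c2ccc(F)cc2)nc1-c1ccnc(O)c1` has not yet been measured. It differs from compound 1 in one place: 2-hydroxypyridin-4-yl in place of 3-cyano-4-fluorophenyl on an aromatic carbon. The carboxymethyl group and the bis(4-fluorophenyl)methyl group are kept. With no measured step of this kind among the compounds shown, the expectation can rest only on the two aryl groups already seen at that position, which give similar numbers in compound 1 and compound 3. The expected step is a modest weakening, a 2.9-fold higher number from compound 1 to compound 4 (0.46 log units; beyond the scatter), with wide uncertainty. Compound 4 is therefore estimated at 1500 nM in this assay, within a range from 300 nM to 8000 nM.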

Compound 4, half-maximal inhibitory concentration: 890 nM
Compound 4: middle estimate off by 1.7-fold (0.23 log units), on the high side; the measured number falls inside the stated range.
By their numbers in this assay, from the lowest: compounds 3, 1 and 4 (each within the scatter of the next). At a limit, above all of these: compound 2.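

In this assay, the change on the aromatic carbon next to the ring nitrogen gives a 1.7-fold higher number from compound 1 to compound 4 (0.23 log units; within the scatter), so 3-cyano-4-fluorophenyl and 2-hydroxypyridin-4-yl cannot be told apart at this position. Within the data shown here, this is the first direct reading at this position with the carboxymethyl and bis(4-fluorophenyl)methyl groups held fixed: an aromatic ring of carbon only, bearing a nitrile and a fluorine, gives way to an aromatic ring with a hetero atom and a hydrogen-bond donor, and the two numbers remain within the scatter of each other. The compounds shown give no measured reason for this result.

On these data alone, it remains open whether the same holds for other groups at this position, such as a phenyl ring bearing an amine or a carboxylic acid, or a saturated ring such as piperidine. As far as these compounds go, it is also open whether 2-hydroxypyridin-4-yl would give a similar reading if the bis(4-fluorophenyl)methyl group were replaced by a methyl group or a longer alkyl chain.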